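The source may report more compounds than this note shows. Statements on the series, on what has been measured and on what is new or still open speak of the compounds shown alone.

Of the compounds shown here, three have been tested so far in an assay on HEK293 cells for displacement of a labelled ligand from growth hormone secretagogue receptor type 1 (Homo sapiens), with a stated time of 60 min; on this read-out lower numbers stand for stronger inhibition and higher numbers for weaker inhibition. Compound 1, with the structure `COCCNCCCS(=O)(=O)c1ccc2nc(NC(=O)NC(=O)c3ccccc3Cl)sc2c1`, gives 8.6 nM. Compound 2, `CN1CCN(CCCS(=O)(=O)c2ccc3nc(NC(=O)NC(=O)c4cc(-n5cccc5)ccc4Cl)sc3c2)CC1`, gives 0.15 nM. Compound 3, `Cc1ccnn1-c1ccc(Cl)c(C(=O)NC(=O)Nc2nc3ccc(S(=O)(=O)C4CCN(C)CC4)cc3s2)c1`, gives 33 nM, the highest of the three numbers, so it is the weakest binder of this set; its gap to compound 1 and its much larger gap to compound 2 both lie beyond the usual scatter.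

The next compound, compound 4, has the structure `CN1CCC(S(=O)(=O)c2ccc3nc(NC(=O)NC(=O)c4cc(N5CCCC5)ccc4Cl)sc3c2)CC1`. Among the compounds with values here, it keeps the shared core of compound 3 and the same sulfone-linked ring, and changes only one group on the chlorine-bearing aromatic ring: pyrrolidin-1-yl in place of 5-methyl-1H-pyrazol-1-yl on an aromatic carbon. A five-membered aromatic ring with 2 hetero atoms is thus swapped for a five-membered non-aromatic ring with 1 hetero atom at the same position.

Compound 2 shows that a small five-membered ring at this position can sit in a very potent compound, although it also differs elsewhere, so its value cannot be read as a clean step. On balance the change is expected to lower the number, with a step of a 5.5-fold lower number from compound 3 to compound 4 (0.74 log units; beyond the scatter). Compound 4 is therefore estimated at 6 nM, within a range of 1.2 nM to 30 nM.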

Compound 4, half-maximal inhibitory concentration: 0.92 nM
Estimate against measurement, compound 4: 6.5-fold (0.81 log units) above, and the stated range ends above it.
By their numbers in this assay, from the lowest: compound 2; then compound 4; then compound 1; then compound 3.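

Within the data shown here, this is the first step in the set between compounds that differ in one place only, so the group on the aromatic carbon para to a chloro group can now be read on its own. In this assay, pyrrolidin-1-yl in place of 5-methyl-1H-pyrazol-1-yl gives a 36-fold lower number from compound 3 to compound 4 (1.55 log units; beyond the scatter), a large change from a single swap, which shows that the read-out depends strongly on what sits at this place and that an aromatic ring there is not needed for a low number, at least with the shared core and sulfone-linked ring of these two compounds. No measurement shown here accounts for the size of this step.

The swap alters several things at once: the ring stops being aromatic, it holds one nitrogen instead of two, and the methyl group is gone, so the compounds shown do not separate these changes. Also open, on these data alone, is how an unmethylated pyrazol-1-yl, an open-chain dimethylamino group or a six-membered piperidin-1-yl ring would behave at this place on the same core.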